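The source may report more compounds than this note shows. Statements on the series, on what has been measured and on what is new or still open speak of the compounds shown alone.

Of the compounds shown here, three built on one shared core have been measured in a functional assay on DU-145 cells (Homo sapiens) for inhibition, read by trypan blue exclusion, with a stated time of 96 h; a higher number here means a weaker inhibitor of growth, a lower number a stronger inhibitor of growth. Compound 1 `Nc1c(Br)cc(Br)cc1/C=C(\C(=O)c1ccc(Br)cc1)S(=O)(=O)c1ccc(Br)cc1` gives 25000 nM. Compound 2 `O=C(/C(=C\c1ccc(Cl)c([N+](=O)[O-])c1)S(=O)(=O)c1ccc(Br)cc1)c1ccc(Br)cc1` gives 10000 nM, and compound 3 `COc1ccc(/C=C(\C(=O)c2ccc(Br)cc2)S(=O)(=O)c2ccc(Br)cc2)cc1` gives 25000 nM. Compound 3 stands level with compound 1, the two together giving the highest numbers of the three; its nearest neighbour is compound 1, with no change at the digits printed from compound 1 to compound 3 (within the scatter), and its furthest is compound 2, with a 2.5-fold higher number from compound 2 to compound 3 (0.40 log units; beyond the scatter).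

The new compound 4 `O=C(/C(=C\c1c[nH]c2ccccc12)S(=O)(=O)c1ccc(Br)cc1)c1ccc(Br)cc1` differs from compound 3 in one place: 1H-indol-3-yl in place of 4-methoxyphenyl on a double-bonded chain carbon bound to a double-bonded chain carbon. The measured steps that bear on this change are those at the same place, namely no change at the digits printed from compound 1 to compound 3 (within the scatter) and a 2.5-fold higher number from compound 2 to compound 3 (0.40 log units; beyond the scatter). Exchanging the group on that double-bonded chain carbon has so far moved this assay only modestly, and in one case not beyond the scatter. For the measured compounds named here, no measured compound carries a 1H-indol-3-yl group there, so the direction for compound 4 cannot be read from the data. The step expected from compound 3 to compound 4 is a 1.3-fold lower number from compound 3 to compound 4 (0.10 log units; within the scatter), which means a number roughly within the scatter of compound 3. Compound 4 is therefore estimated at 20000 nM, with a range from 6000 nM to 50000 nM.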

Compound 4, concentration for 50% growth inhibition: 25000 nM
For compound 4 the middle estimate is 1.3-fold (0.10 log units) below the measured one; the measured number falls inside the stated range.
By their numbers in this assay, from the lowest: compound 2; then compounds 1, 3 and 4 (each within the scatter of the next).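

In this assay, the 1H-indol-3-yl group brings to this double-bonded chain carbon a five-membered aromatic ring with a hetero atom, a feature that no earlier group there carries, yet exchanging it for 4-methoxyphenyl leaves the number in place (no change at the digits printed from compound 3 to compound 4 (within the scatter)). The comparison with the heavily substituted 2-amino-3,5-dibromophenyl group reads the same way (no change at the digits printed from compound 1 to compound 4 (within the scatter)), so three quite different groups at this place now sit together. Against them stands only the 4-chloro-3-nitrophenyl group of compound 2, and the new compound confirms that separation with a step of the same size as before (a 2.5-fold higher number from compound 2 to compound 4 (0.40 log units; beyond the scatter)).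

No measurement shown here explains why compound 2 stands apart from the other three. Still open, on these data alone, is whether the chlorine or the nitro group matters more, which 4-chlorophenyl and 3-nitrophenyl at this place could help to separate, and how a plain phenyl or a phenyl bearing a carboxylic acid would compare with these four compounds.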